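This account rests on a few compounds, and the source may have more. Where it says the series, first, only, none or still open, it means among the compounds named here.

Measured so far in a physicochemical assay for lipophilicity; a higher number here means a more lipophilic compound, a lower number a more polar compound:

- compound 1, `CCOC(=O)/C=C(C)/C=C/CC(C)CCC=C(C)C`, gives 6.19
- compound 2, `C=C(C)CCCC(C)C/C=C/C(C)=C/C(=O)OCC`, gives 6.19
- compound 3, `CC(C)=CCCC(C)C/C=C/C(C)=C/C(=O)OC(C)C`, gives 6.6

Compound 4, `C=C(C)CCCC(C)C/C=C/C(C)=C/C(=O)OC(C)C`, has not yet been measured. It is reached from compound 3 by one change: 2-methylprop-2-en-1-yl in place of 2-methylprop-1-en-1-yl on a saturated chain carbon, four bonds along the chain from a double-bonded chain carbon. This is the same change that separates the two measured compounds 1 and 2, namely (2-methylprop-2-en-1-yl in place of 2-methylprop-1-en-1-yl on a saturated chain carbon, four bonds along the chain from a double-bonded chain carbon). Its place reads the same word for word in both pairs, so the two changes are the same and not merely the same kind. In that measured pair it produced no change at the digits printed from compound 1 to compound 2 (within the scatter).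

The two cores on which the change is made differ themselves, by methyl in place of hydrogen on a saturated chain carbon bound to an oxygen next to a carbonyl group and a saturated chain carbon. That difference gave a number 0.41 log units higher from compound 1 to compound 3 (beyond the scatter). Compound 3 stands highest of the three measured compounds.

For compound 4 only a modest shift, if any, is expected, because no change at the digits printed from compound 1 to compound 2 (within the scatter) shows the same change leaving this assay essentially untouched. The step from compound 3 to compound 4 is therefore estimated at no change at the digits printed from compound 3 to compound 4 (within the scatter). Compound 4 is expected to come out near 6.6, most likely between 6.3 and 6.9.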

Compound 4, partition coefficient: 6.6
Compound 4: the middle estimate sits on the measured number at the digits printed; low and high end bracket the measured number.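

In this assay, putting 2-methylprop-2-en-1-yl in place of 2-methylprop-1-en-1-yl gives no change at the digits printed from compound 3 to compound 4 (within the scatter) and the same change earlier gave no change at the digits printed from compound 1 to compound 2 (within the scatter) so on these two cores it carried over with the same outcome. Read the other way, methyl in place of hydrogen on a saturated chain carbon bound to an oxygen next to a carbonyl group and a saturated chain carbon gives a number 0.41 log units higher from compound 2 to compound 4 (beyond the scatter) and matches a number 0.41 log units higher from compound 1 to compound 3 (beyond the scatter) so in these four compounds each change reads the same whichever form of the other is present. Two cores are too few to make this a rule for the series, and no measurement at hand explains the result.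

Going by these compounds, it remains open whether the same change would still leave the number in place on a core carrying a carboxylic acid or an amine instead of the ester. On these data alone, it is equally open whether the methyl step would repeat with a longer chain on that oxygen.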